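The source may hold more compounds than are shown below. What is called first, only, known or untested is meant among the compounds shown, and "the series" means these compounds.

Measured compounds and their values:

compound 1, `Cc1cc(Nc2ccn(Cc3cccc4ccccc34)n2)n2nc(SCc3ccc(Br)cc3)nc2n1`: 5660 nM
compound 2, `Cc1cc(Nc2cc(-c3ccccc3)[nH]n2)n2nc(SCc3ccc([N+](=O)[O-])cc3)nc2n1`: 7980 nM
compound 3, `Cc1ccc(CSc2nc3nc(C)cc(Nc4cc(-c5ccccc5)[nH]n4)n3n2)cc1`: 7310 nM

The three measured compounds were tested in a functional assay on PC-9 cells (Homo sapiens) for inhibition, read by MTT assay, with a stated time of 72 h; on this read-out higher numbers stand for weaker inhibition and lower numbers for stronger inhibition. Compound 1 `Cc1cc(Nc2ccn(Cc3cccc4ccccc34)n2)n2nc(SCc3ccc(Br)cc3)nc2n1` gives 5660 nM. Compound 2 `Cc1cc(Nc2cc(-c3ccccc3)[nH]n2)n2nc(SCc3ccc([N+](=O)[O-])cc3)nc2n1` gives 7980 nM. Compound 3 `Cc1ccc(CSc2nc3nc(C)cc(Nc4cc(-c5ccccc5)[nH]n4)n3n2)cc1` gives 7310 nM, the second highest of the three numbers; its nearest neighbour is compound 2 and its furthest is compound 1, and both gaps lie within the scatter. Going by the values given here, the only single-point step among the measured compounds runs a 1.1-fold lower number from compound 2 to compound 3 (0.04 log units; within the scatter), a change of a methyl in place of a nitro on an aromatic carbon, and it moved nothing beyond the scatter.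

Compound 4 `Cc1cc(Nc2cc(-c3ccccc3)[nH]n2)n2nc(SCc3csc4ccccc34)nc2n1` differs from compound 3 in one place: 1-benzothiophen-3-yl in place of 4-methylphenyl on a saturated chain carbon bound to a sulfur. Among the compounds with values here, no measured step bears directly on this exchange of the group on the saturated chain carbon bound to a sulfur; the one step recorded, a 1.1-fold lower number from compound 2 to compound 3 (0.04 log units; within the scatter), changed a substituent on that same benzyl ring without effect, and compound 1 carries a different group at the same place with 5660 nM, which also sits within the scatter of compound 3. The expected step from compound 3 to compound 4 is therefore a 1.3-fold lower number from compound 3 to compound 4 (0.12 log units; within the scatter), small and not beyond the scatter. Compound 4 is estimated at 5500 nM in this assay, with a range from 2000 nM to 15000 nM.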

Compound 4, half-maximal inhibitory concentration: 4420 nM
Compound 4: the middle estimate sits 1.2-fold (0.09 log units) above what was measured; the measured number falls inside the stated range.
By their numbers in this assay, from the lowest: compounds 4, 1, 3 and 2 (each within the scatter of the next).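

In this assay, the earlier step changed only a substituent on the benzyl ring, whereas this exchange replaces the whole aromatic group on the saturated chain carbon bound to a sulfur. Neither step that replaces the group moves the number beyond the scatter (a 1.7-fold lower number from compound 3 to compound 4 (0.22 log units; within the scatter); a 1.8-fold lower number from compound 2 to compound 4 (0.26 log units; within the scatter)), so in these compounds the position takes 1-benzothiophen-3-yl, with its five-membered aromatic ring containing a hetero atom and its 9 heavy atoms, as readily as the single six-membered aromatic rings of 4-methylphenyl and 4-nitrophenyl. No measurement shown here explains why these numbers stay so close.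

Compounds 2, 3 and 4 all lie within the scatter of one another, so the shown compounds do not identify any group at this position that moves the number beyond the scatter. On these data alone, it remains open whether an amine, a carboxylic acid or a longer chain in place of the aromatic group on that saturated chain carbon would leave the number as it is or shift it clearly in either direction.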